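Removing a chloro on a dichlorophenyl ether: what to expect

The source may hold more compounds than are shown below. What is called first, only, known or untested is meant among the compounds shown, and "the series" means these compounds.

Three compounds sharing a spiro-fused guanidine-like core attached through a short oxygen-linked chain to a chlorinated phenyl ring have been tested in a functional assay on HCT-116 cells (Homo sapiens) for antiproliferative activity, read by MTT assay, with a stated time of 72 h; on this read-out lower numbers stand for stronger inhibition and higher numbers for weaker inhibition. Compound 1 `NC1=NC2(CCSCC2)N(OCCCOc2ccc(Cl)c(Cl)c2)C(N)=N1` gives 1 nM in this assay. Compound 2 `NC1=NC2(CCSCC2)N(OCCCOc2cccc(Cl)c2)C(N)=N1` gives 1 nM. The two differ by one change, (hydrogen in place of chloro on an aromatic carbon), and the step of no change at the digits printed from compound 1 to compound 2 (within the scatter) shows that taking this chloro away left the result where it was. Compound 3 `NC1=NC2(CCOCC2)N(OCCCOc2cccc(Cl)c2Cl)C(N)=N1` gives 5 nM, a higher number than either compound 1 or compound 2; how the core of compound 3 differs from the core of compound 1 is not broken down here.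

Compound 4 `NC1=NC2(CCOCC2)N(OCCCOc2ccccc2Cl)C(N)=N1` has not yet been tested. Among the measured compounds shown here, it differs from compound 3 by hydrogen in place of chloro on an aromatic carbon, a change of the same kind as the one from compound 1 to compound 2, though not the same: in compound 1 the departing chloro sits para to a large group, whereas in compound 3 it sits meta to a large group, and the cores differ as well. Because the step of no change at the digits printed from compound 1 to compound 2 (within the scatter) was flat, the expected step of a 1.2-fold higher number from compound 3 to compound 4 (0.08 log units; within the scatter) is also small, with compound 4 expected to stay near compound 3. On that basis compound 4 is estimated to give 6 nM in this assay, most likely between 2 nM and 20 nM.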

Compound 4, half-maximal inhibitory concentration: 70 nM
Estimate against measurement, compound 4: 12-fold (1.07 log units) below, and the stated range ends below it.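

In this assay, going from the 2,3-dichlorophenyl group to the 2-chlorophenyl group gave a 14-fold higher number from compound 3 to compound 4 (1.15 log units; beyond the scatter) and so a clear loss of inhibition, which means that a chloro that could be dropped without effect in one pair of compounds could not be dropped in the other. This does not show that the core alone decides the outcome: the two pairs differ in their cores and also in where the departing chloro stands on the ring, and two steps cannot pull these differences apart. What can be said is that a flat step on one core was no reliable guide to the same change on the other, and the two steps stand clearly apart: the same change on two cores in this assay, no change at the digits printed (within the scatter) from compound 1 to compound 2 and a 14-fold higher number (1.15 log units; beyond the scatter) from compound 3 to compound 4, 14-fold (1.15 log units) apart, beyond the scatter of two such steps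

Still open, going by these compounds, is whether the 2-chlorophenyl group would lose as much on the core of compound 1, which would point to the place of the chloro rather than to the core. Also open, on these data alone, is how a fluoro or a methyl group in the place of the departing chloro would read, and whether a longer chain between the core and the ring would alter the size of this step.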